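The compounds below may be only part of what the source reports. "The series", "measured", "known", "first", "only" and "open" are said of these compounds alone.

In an ADME assay on MIA PaCa-2 cells (Homo sapiens) for cytotoxicity, read by MTT assay, with a stated time of 72 h (on this read-out lower numbers stand for stronger inhibition and higher numbers for weaker inhibition), compound 3 `COc1cc(C2=C(c3ccccc3)C(O[SiH2]C(C)(C)C)CC2=O)cc(OC)c1OC` gives > 100 ug/mL as its result, which is a limit of the assay and not a number. Compound 1 `COc1ccc(OC)c(C2=C(c3cc(OC)c(OC)c(OC)c3)C(=O)CC2O[SiH2]C(C)(C)C)c1` gives > 100 ug/mL as a limit too. Compound 2 `COc1ccc(C2=C(c3cc(OC)c(OC)c(OC)c3)C(=O)CC2O)cc1O`, which carries the 3-hydroxy-4-methoxyphenyl group, gives > 100 ug/mL as a limit as well. The whole picture so far is therefore the limit of > 100 ug/mL in this assay, at which 3 of the 3 values shown sit, and no measured number exists yet.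

The next compound is compound 4 `COc1ccc(C2=C(c3cc(OC)c(OC)c(OC)c3)C(=O)CC2O[SiH2]C(C)(C)C)cc1O`, and the change is 3-hydroxy-4-methoxyphenyl in place of phenyl on a double-bonded ring carbon with 3-hydroxy-4-methoxyphenyl in place of phenyl on a double-bonded ring carbon. For the measured compounds named here, the one measured step at such a carbon is a step that the two limits leave unreadable from compound 1 to compound 3 and it concerns phenyl in place of 2,5-dimethoxyphenyl, so it gives no size to carry over. What remains is the result for compound 2, whose > 100 ug/mL stands as a limit even with the incoming group in place. No step beyond the usual scatter is therefore expected, and the most likely outcome is another report at the limit. The estimated move is a number no higher from compound 3 to compound 4 (the limit leaves the size open) in this assay with no direction that the data can support. For compound 4 the expected value is 100 ug/mL with an estimated range from 30 ug/mL to 150 ug/mL on the same read-out.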

Compound 4, half-maximal inhibitory concentration: 55 ug/mL
Compound 4: middle estimate off by 1.8-fold (0.26 log units), on the high side, within the range that was stated.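

In this assay, for the compounds shown here, the 3-hydroxy-4-methoxyphenyl group on the double-bonded ring carbon comes with the only measured number so far: replacing phenyl gives an at least 1.8-fold lower number from compound 3 to compound 4 (0.25 log units; that floor lies within the scatter), and replacing 2,5-dimethoxyphenyl gives an at least 1.8-fold lower number from compound 1 to compound 4 (0.25 log units; that floor lies within the scatter). That group alone does not bring a number within the limit of the assay, as the other change into compound 4, a group of 5 heavy atoms (4 carbon, 1 silicon; no ring) in place of a hydrogen atom on an oxygen on a saturated carbon, gives an at least 1.8-fold lower number from compound 2 to compound 4 (0.25 log units; that floor lies within the scatter). So a measurable number appears here only with both features together, yet each step is known only as a floor within the usual scatter, and the other compounds remain at a limit and not at a number: the limit of > 100 ug/mL in this assay, at which 3 of the 4 values shown sit.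

The compounds shown leave open whether the hydroxy or the methoxy of the entering group matters more, and how large any of these steps really is. From the compounds shown here alone, it also remains open what an amine or a carboxylic acid on that aromatic ring would do, or a longer carbon chain in place of the silicon-bearing group on the oxygen.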